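Ring nitrogen substituents in compounds 1 to 3

The source may report more compounds than this note shows. Statements on the series, on what has been measured and on what is new or still open speak of the compounds shown alone.

Measured so far in an ADME assay on microsomes from liver (Mus musculus) for metabolic stability, read by LC-MS, with a stated time of 10 min; a lower number here means that less of the compound is left, a higher number that more of the compound is left:
- compound 1 `CN(C[C@H]1Cc2c(cccc2N2CCN(C3CC3)CC2)CN1)[C@H]1CCCc2cccnc21`: 7%
- compound 2 `CC(C)N1CCN(c2cccc3c2C[C@H](CN(C)[C@H]2CCCc4cccnc42)NC3)CC1`: 15.1%

Compound 2 gives 15.1% and cannot be separated from compound 1. For the measured compounds named here, the one measured step is a number 8.1 percentage points higher from compound 1 to compound 2 (within the scatter), and it exchanges cyclopropyl for isopropyl on an amine nitrogen in a ring.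

The next change leads to compound 3 `CN(C[C@H]1Cc2c(cccc2N2CCN(c3cccc(C(F)(F)F)c3)CC2)CN1)[C@H]1CCCc2cccnc21`: 3-(trifluoromethyl)phenyl in place of isopropyl on an amine nitrogen in a ring. The measured step concerns the same kind of nitrogen as this change. It is only a weak guide. It swaps one small group for another, whereas the entering group here is much larger and brings an aromatic ring. Going by the values given here, no measured compound carries an aromatic ring at this place, so the data give no direction. The expectation therefore starts from compound 2 at 15.1%, and no step beyond the scatter is expected, though with wide uncertainty. The estimated change is a number 1.9 percentage points higher from compound 2 to compound 3 (within the scatter). For compound 3 the estimated value is 17%, with an expected range of 4% to 45%.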

Compound 3, percent of the compound remaining: 72.3%
Estimate against measurement, compound 3: 55.3 percentage points below, and the stated range ends below it.
By their numbers in this assay, from the lowest: compounds 1 and 2 (each within the scatter of the next); then compound 3.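

In this assay this amine nitrogen turns out to be a place where a single change moves the read-out strongly: 3-(trifluoromethyl)phenyl in place of isopropyl gives a number 57.2 percentage points higher from compound 2 to compound 3 (beyond the scatter), and in place of cyclopropyl it gives a number 65.3 percentage points higher from compound 1 to compound 3 (beyond the scatter). The earlier exchange of cyclopropyl for isopropyl stayed within the scatter, so the two small groups gave no sign of how much this nitrogen substituent can matter, and only the larger group bearing an aromatic ring shows it. Nothing available explains the size of this step.

The entering group differs from the small groups in two ways at once, through the aromatic ring and through the trifluoromethyl on it, so the compounds shown do not separate the share of each; a plain phenyl group at this nitrogen would divide the two. Also open, as far as these compounds go, is whether the result depends on the aromatic ring sitting directly on the nitrogen, which a benzyl group or a pyridine ring at the same place would begin to test.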